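Working notes: 4-nitrophenyl to 4-fluorophenyl in the series

The source may report more compounds than this note shows. Statements on the series, on what has been measured and on what is new or still open speak of the compounds shown alone.

Measured in a functional assay on SUP-B15 cells (Homo sapiens) for antiproliferative activity, with a stated time of 72 h; on this read-out lower numbers stand for an effect already at smaller amounts and higher numbers for an effect only at larger amounts of compound:
- compound 1 `COc1ccc(-c2cc(=O)c3c(OC)cc(OC)cc3[nH]2)cc1`: > 62000 nM
- compound 2 `COc1ccc(-c2cc(=O)c3c(OC)cc(OC)cc3n2S(=O)(=O)c2ccc([N+](=O)[O-])cc2)cc1`: 17100 nM

The entry for compound 1 is a limit of this assay and not a number. Among the measured compounds shown here, compound 2 gives 17100 nM, the only actual number so far.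

The next compound is compound 3 `COc1ccc(-c2cc(=O)c3c(OC)cc(OC)cc3n2S(=O)(=O)c2ccc(F)cc2)cc1`, which differs from compound 2 as follows: fluoro in place of nitro on an aromatic carbon. This is fluoro in place of nitro on an aromatic carbon, para to a large group. For the measured compounds named here, no measured step covers this change, so the expectation starts from compound 2 at 17100 nM. In this assay a small step is expected, leaning slightly towards higher numbers and possibly no larger than the scatter. The estimated change is a 1.3-fold higher number from compound 2 to compound 3 (0.11 log units; within the scatter). Compound 3 is expected at about 22000 nM, with an estimated range of 8000 nM to 60000 nM.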

Compound 3, half-maximal effective concentration: > 65500 nM
Compound 3 was reported as a limit (the forecaster's own chance of this, stated with the estimate: 20%); middle value at least 2.9-fold (0.47 log units) from the limit.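

In this assay, going from 4-nitrophenyl to 4-fluorophenyl gives an at least 3.8-fold higher number from compound 2 to compound 3 (0.58 log units; beyond the scatter), so at this place on the aromatic ring fluoro does not stand in for nitro. The entry for compound 3 is a limit of the assay and not a number: the limit of > 65500 nM in this assay, at which 1 of the 3 values shown sits.

Compound 2 remains the only one of the three with an actual number, so the sulfonyl link alone does not secure a measurable value; the step from compound 1 to compound 3 cannot be read, as both entries are limits.

Open, on these data alone, is whether a measurable value needs nitro itself or would also appear with another group at this place, such as an amine, a nitrile or a carboxylic acid. As far as these compounds go, the full size of the step also stays open, since it ends at a limit.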